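A few compounds are considered here, and "the series" means these few. Any claim that something is new, unique, unknown or untested is made for them only; others in the source may bear on it.

Two compounds share a core in which a pyridyl group and a substituted phenyl ring sit on a pyrazole that is itself attached to a urea-bearing phenyl ring. Compound 1 `O=C(Nc1cccc(-n2cc(-c3ccncc3)c(-c3ccc(Cl)c(O)c3)n2)c1)Nc1cccc(C(F)(F)F)c1` carries a 4-chloro-3-hydroxyphenyl group and a trifluoromethylphenyl urea; in a functional assay on SK-OV-3 cells (Homo sapiens) for inhibition, read by sulforhodamine B assay, with a stated time of 48 h (a lower number here means a stronger inhibitor of growth, a higher number a weaker inhibitor of growth), compound 1 gives 4970 nM. Compound 2 `COc1cc(-c2nn(-c3cccc(NC(=O)Nc4ccc(Cl)c(Cl)c4)c3)cc2-c2ccncc2)ccc1Cl` carries a 4-chloro-3-methoxyphenyl group and a dichlorophenyl urea, and in this assay compound 2 gives 1930 nM. Compound 2 thus has the lower of the two numbers, the number for compound 1 being higher by a margin beyond the usual scatter.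

Compound 3 `O=C(Nc1cccc(-n2cc(-c3ccncc3)c(-c3ccc(Cl)c(O)c3)n2)c1)Nc1ccc(Cl)c(Cl)c1` keeps the dichlorophenyl urea of compound 2 and differs from it in one place: hydrogen in place of methyl on an oxygen on an aromatic ring, that is, methoxy to hydroxy. Among the compounds with values here, no measured pair isolates this change, so the expectation rests on the two values seen. Compound 3 is estimated at 2600 nM, with a range of 1000 nM to 6500 nM. The expected step of a 1.3-fold higher number from compound 2 to compound 3 (0.13 log units; within the scatter) is a modest weakening, close to the scatter.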

Compound 3, concentration for 50% growth inhibition: 1200 nM
Compound 3: middle estimate off by 2.2-fold (0.34 log units), on the high side; low and high end bracket the measured number.
By their numbers in this assay, from the lowest: compounds 3 and 2 (each within the scatter of the next); then compound 1.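

In this assay, with the 3,4-dichlorophenyl urea held constant, the change from methoxy to hydroxy gives a 1.6-fold lower number from compound 2 to compound 3 (0.21 log units; within the scatter) and so does not separate the two groups at this position. The hydroxy group on the 4-chloro-3-hydroxyphenyl ring is also now held constant across a second pair, where 3,4-dichlorophenyl in place of 3-(trifluoromethyl)phenyl on the amide-type nitrogen gives a 4.1-fold lower number from compound 1 to compound 3 (0.62 log units; beyond the scatter) and marks a modest gain in growth inhibition. Within the data shown here, of the two single changes, only the one on the urea lies beyond the scatter.

As far as these compounds go, whether an ethoxy group or an amine at the position of the hydroxy would keep the number in this range remains open. Nothing given here explains either step.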